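Chain lengthening in a bromomaleimide indole series

A few compounds are considered here, and "the series" means these few. Any claim that something is new, unique, unknown or untested is made for them only; others in the source may bear on it.

Of the compounds shown here, three in this set have been measured in a physicochemical assay for lipophilicity; a higher number here means a more lipophilic compound, a lower number a more polar compound. Compound 1 `CCc1ccc2[nH]c(-c3ccccc3)c(C3=C(Br)C(=O)NC3=O)c2c1` gives 3.15. Compound 2 `CCCCc1ccc2[nH]c(-c3ccccc3)c(C3=C(Br)C(=O)NC3=O)c2c1` gives 3.74, and compound 3 `CCCCc1ccc2[nH]c(-c3cccc(OC)c3)c(C3=C(Br)C(=O)NC3=O)c2c1` gives 3.81. Compound 3 stands highest of the three numbers, though its gap to compound 2 is within the scatter; only against compound 1 is it clearly apart.

Between compound 1 and compound 2 the structural difference is ethyl in place of hydrogen on a saturated chain carbon, two bonds along the chain from an aromatic carbon, and that change carried a step of a number 0.59 log units higher from compound 1 to compound 2 (beyond the scatter). Between compound 2 and compound 3 the change is a methoxy in place of hydrogen on an aromatic carbon, which gave a number 0.07 log units higher from compound 2 to compound 3 (within the scatter). The difference between the core of compound 1 and the core of compound 3 is not broken down here.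

The unmeasured compound 4 `CCCCCCc1ccc2[nH]c(-c3cccc(OC)c3)c(C3=C(Br)C(=O)NC3=O)c2c1` differs from compound 3 by ethyl in place of hydrogen on a saturated chain carbon, four bonds along the chain from an aromatic carbon. This is the same kind of change as that from compound 1 to compound 2, but not the same: there the entering ethyl sat two bonds along the chain from an aromatic carbon, here it sits four bonds along the chain from an aromatic carbon. Resting on the step of a number 0.59 log units higher from compound 1 to compound 2 (beyond the scatter), a step of similar size is expected here, giving an estimated a number 0.59 log units higher from compound 3 to compound 4 (beyond the scatter) in this assay. Compound 4 is therefore expected to give about 4.4, most likely between 4 and 4.9.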

Compound 4, partition coefficient: 4.26
Beside the measured number, compound 4's estimate is 0.14 log units above it; the range from low to high includes it.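

In this assay, the ethyl in place of hydrogen gave a number 0.45 log units higher from compound 3 to compound 4 (beyond the scatter), and alongside a number 0.59 log units higher from compound 1 to compound 2 (beyond the scatter) on the core of compound 1, this makes two steps in the same direction, each beyond the scatter. Among these compounds, this shows that the direction of the change held from one core to the other, but with only two pairs it does not establish a general rule for the series, and since both the core and the place on the chain differ between the pairs, it cannot separate what either contributes to the size of the step. Nothing in the information available speaks to what lies behind either step.

The compounds shown leave open whether the same direction would hold if the chain of compound 4 were extended further, for instance to an octyl or decyl chain, or if the chain ended in an amine or a carboxylic acid. They also leave open whether methoxy in place of hydrogen on an aromatic carbon would stay within the scatter on the shorter chain of compound 1 or on the longer chain of compound 4.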